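The compounds below may be only part of what the source reports. "The series", "measured", "known", "first", "only" and "open" are said of these compounds alone.

Compound 1 `Cn1cncc1C(OCc1ccc(C#N)cc1C#Cc1ccc(C#N)cc1)c1ccc(C#N)cc1` is measured in a functional assay on NIH3T3 cells (Mus musculus) (a higher number here means that more compound is needed for the effect, a lower number that less compound is needed), at 11.6 nM. Compound 2 `Cn1cncc1C(OCc1ccc(C#N)cc1-c1ccc(-c2ccccc2)cc1)c1ccc(C#N)cc1` reaches the limit of this assay, < 0.1 nM, so for it only a limit and no number is known.

Compound 1 thus holds the only number shown in this assay, the one further value being a limit. Its step to compound 2 is large: an at least 110-fold lower number from compound 1 to compound 2 (2.06 log units; beyond the scatter), with compound 2 sitting at the limit of < 0.1 nM in this assay, at which 1 of the 2 values shown sits. Compound 3 `Cn1cncc1C(OCc1ccc(C#N)cc1C#CCCCCO)c1ccc(C#N)cc1`, not yet measured, differs from compound 1 at the same triple-bonded carbon: 4-hydroxybutyl in place of 4-cyanophenyl on a triple-bonded carbon. The measured step from compound 1 to compound 2 is the only one that bears on this change, and it concerns a different replacement at that carbon, so it gives little direct guidance. The 4-hydroxybutyl group brings no ring where the 4-cyanophenyl group had one. Compound 3 is therefore expected to need somewhat more compound than compound 1, an estimated step of a 2.2-fold higher number from compound 1 to compound 3 (0.33 log units; beyond the scatter). Compound 3 is estimated at 25 nM, within 8 nM to 80 nM.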

Compound 3, half-maximal effective concentration: 20.9 nM
The estimate for compound 3 lay 1.2-fold (0.08 log units) above the measured number, and the stated range covers the measured number.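

In this assay, the ring-free 4-hydroxybutyl group on the triple-bonded carbon gives a 1.8-fold higher number from compound 1 to compound 3 (0.26 log units; within the scatter), so the 4-cyanophenyl ring is not needed there to stay within the scatter of compound 1. The step that removes the triple bond is of another order: an at least 200-fold higher number from compound 2 to compound 3 (2.32 log units; beyond the scatter), and among the compounds shown, changing the group at the far end of the triple bond matters much less than exchanging the whole 2-(4-cyanophenyl)ethynyl or 6-hydroxyhex-1-yn-1-yl unit for 4-phenylphenyl. Compound 2 is known only as a limit, so that step has no exact size: the limit of < 0.1 nM in this assay, at which 1 of the 3 values shown sits.

On these data alone, it stays open whether an amine or a carboxylic acid at the end of the chain, or a longer chain, would also leave the number where it is. As far as these compounds go, it also stays open whether a 4-phenylphenyl group held on a triple bond would behave like compound 2.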